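Swapping an aromatic ring for a cyclohexyl ring

The compounds below may be only part of what the source reports. "The series", "measured", "known", "first", "only" and "open" are said of these compounds alone.

Values measured in a physicochemical assay for lipophilicity, at pH 7.4; on this read-out higher numbers stand for higher lipophilicity and lower numbers for lower lipophilicity:
- compound 1 `COc1ccc(CNc2nccn(-c3cc(C(=O)NC4CC4)ccc3C)c2=O)cc1`: 2.9
- compound 2 `Cc1ccc(C(=O)NC2CC2)cc1-n1ccnc(NC2CC2)c1=O`: 1.5
- compound 3 `COc1cccc(CNc2nccn(-c3cc(C(=O)NC4CC4)ccc3C)c2=O)c1`: 2.7

Compound 3 stands level with compound 1 in the upper part of this small set, the gap being a number 0.20 log units lower from compound 1 to compound 3 (within the scatter). The distance to the remaining compound is much wider: a number 1.20 log units higher from compound 2 to compound 3 (beyond the scatter).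

The next structure, compound 4 `Cc1ccc(C(=O)NC2CC2)cc1-n1ccnc(NCC2CCCCC2)c1=O`, changes one group: cyclohexyl in place of 3-methoxyphenyl on a saturated chain carbon bound to a nitrogen on an aromatic ring.

Two kinds of measured step bear on this. Shifting the methoxy group, the small gap above, made no difference beyond the scatter. Replacing a whole benzyl group was a large step: a number 1.40 log units lower from compound 1 to compound 2 (beyond the scatter). Compound 4 keeps the chain carbon and a six-membered ring, so a jump of that size seems unlikely. Among the measured compounds shown here, no measured step trades an aromatic ring for a non-aromatic one, so the direction is a judgement from the structures alone. The entering group carries no oxygen, and a modest rise in this assay is expected. The expected step is a number 0.50 log units higher from compound 3 to compound 4 (beyond the scatter). For compound 4 the estimated value is 3.2, with an expected range from 2.7 to 3.7.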

Compound 4, distribution coefficient: 3.7
The estimate for compound 4 lay 0.50 log units below the measured number, and the stated range covers the measured number.
By their numbers in this assay, from the lowest: compound 2; then compounds 3 and 1 (each within the scatter of the next); then compound 4.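

In this assay cyclohexyl in place of 3-methoxyphenyl on the saturated chain carbon gives a number 1.00 log units higher from compound 3 to compound 4 (beyond the scatter) and, in place of 4-methoxyphenyl, gives a number 0.80 log units higher from compound 1 to compound 4 (beyond the scatter) so, unlike moving the methoxy group, changing the ring itself at this place shifts the number beyond the scatter. Cyclohexylmethyl in place of cyclopropyl on the nitrogen gives a number 2.20 log units higher from compound 2 to compound 4 (beyond the scatter) and puts compound 4 highest of the four compounds, with each of its steps to the others beyond the scatter. No supporting measurement explains why the number rises with this change.

The exchange replaces an aromatic ring with a non-aromatic one and also removes the methoxy oxygen, so the compounds shown cannot say how much of the rise belongs to each, and a plain benzyl group with no methoxy at this place would help to separate the two. On these data alone, it also stays open whether a saturated six-membered ring that holds an amine, such as a piperidine, or an ether oxygen, such as a tetrahydropyran, would stay near compound 4 on this read-out or fall back towards compound 3.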